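Moving a methoxyethoxy group across the shared core

A few compounds are considered here, and "the series" means these few. Any claim that something is new, unique, unknown or untested is made for them only; others in the source may bear on it.

Measured so far:
compound 1 `Fc1ccc(-c2nn3c(NC4CCCC4)cc(NC4CCCC4)cc3c2-c2ccnc(NC3CCCC3)n2)cc1`: > 40000 nM
compound 2 `COCCOc1cc(NC2CCCC2)cc2c(-c3ccnc(NC4CCCC4)n3)c(-c3ccc(F)cc3)nn12`: 32500 nM

The measurement of interest is an ADME assay on Vero cells (Chlorocebus sabaeus) for cytotoxicity; a higher number here means that more compound is tolerated, a lower number that less compound is tolerated. For compound 1 only a limit is known: in this assay compound 1 gives > 40000 nM, which is a limit of the assay and not a number, as noted in the limit of > 40000 nM in this assay, at which 1 of the 2 values shown sits. Compound 2, in which a 2-methoxyethoxy group replaces one cyclopentylamino group on an aromatic carbon of the core, gives 32500 nM in this assay. The step of an at least 1.2-fold lower number from compound 1 to compound 2 (0.09 log units; that floor lies within the scatter) lies within the scatter of repeated measurements, so the two compounds cannot be told apart on this number.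

Compound 3 `COCCOc1cc(NC2CCCC2)n2nc(-c3ccc(F)cc3)c(-c3ccnc(NC4CCCC4)n3)c2c1` carries the same exchange of groups, but at another aromatic carbon of the core: 2-methoxyethoxy in place of cyclopentylamino on an aromatic carbon. Among the compounds with values here, the only measured step that bears on this change is an at least 1.2-fold lower number from compound 1 to compound 2 (0.09 log units; that floor lies within the scatter), and it was no larger than the scatter. The expectation for compound 3 is therefore a number close to that of compound 2, with no step beyond the scatter, because an at least 1.2-fold lower number from compound 1 to compound 2 (0.09 log units; that floor lies within the scatter) showed no clear movement. The estimated value for compound 3 in this assay is 33000 nM, with a range from 15000 nM to 60000 nM, corresponding to an expected step of an at least 1.2-fold lower number from compound 1 to compound 3 (0.08 log units; that floor lies within the scatter).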

Compound 3, half-maximal cytotoxic concentration: > 40000 nM
Compound 3 ended at the assay's limit; the forecaster's own chance of this, stated with the estimate: 40%; middle value at least 1.2-fold (0.08 log units) away from the limit.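

Compound 1 and compound 3 each give only a limit of the assay and not a number, so no step can be read between them: the limit of > 40000 nM in this assay, at which 2 of the 3 values shown sit.

The compounds shown leave open what numbers compound 1 and compound 3 would actually give, and whether the place of the 2-methoxyethoxy group on the shared core matters in this assay.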